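Working notes on cytotoxicity across the series

A few compounds are considered here, and "the series" means these few. Any claim that something is new, unique, unknown or untested is made for them only; others in the source may bear on it.

Measured compounds:
compound 1 `CCc1ccc2[nH]c(=O)c(CN(Cc3cccc(F)c3)Cc3ccc4ccccc4c3)cc2c1`: > 5000 nM
compound 2 `Cc1ccc2cc(CN(Cc3ccc(C(C)(C)C)cc3)C3CCCC3)c(=O)[nH]c2c1`: > 10000 nM
compound 3 `CCCOc1ccc(CN(Cc2ccc(C(C)(C)C)cc2)Cc2cc3cc(C)ccc3[nH]c2=O)cc1`: > 5000 nM

In a toxicity assay on MDCK cells (Canis lupus familiaris) for cytotoxicity, read by crystal violet staining, with a stated time of 48 h (on this read-out lower numbers stand for higher toxicity in this test and higher numbers for lower toxicity in this test), compound 1 gives > 5000 nM, a limit of the test and not a number. Compound 2 gives > 10000 nM in this assay, again a limit. Compound 3 stands at > 5000 nM in this assay, also a limit. None of the three compounds has a resolved number: one value sits at the limit of > 10000 nM in this assay, at which 1 of the 3 values shown sits, and two sit at the limit of > 5000 nM in this assay, at which 2 of the 3 values shown sit. Compound 4 `Cc1ccc2[nH]c(=O)c(CN(Cc3ccc(C(C)(C)C)cc3)C(C)c3ccc(N(C)C)c(Cl)c3)cc2c1` has not been measured. Its change from compound 3 is 1-(3-chloro-4-(dimethylamino)phenyl)ethyl in place of 4-propoxybenzyl on an amine nitrogen. For the measured compounds named here, no step between measured compounds exists to guide the size of this change; the step expected is a step that the limit leaves unreadable from compound 3 to compound 4, none beyond the scatter. Compound 4 is expected at 8000 nM in this assay, within 3000 nM to 30000 nM, most likely reported once more as a limit.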

Compound 4, half-maximal cytotoxic concentration: 9800 nM
Beside the measured number, compound 4's estimate is 1.2-fold (0.09 log units) below it, and the stated range covers the measured number.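

In this assay compound 3 gives > 5000 nM, a limit and not a number. The step to compound 4 therefore cannot be read. The compounds shown leave open whether 1-(3-chloro-4-(dimethylamino)phenyl)ethyl in place of 4-propoxybenzyl changes cytotoxicity at all.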